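Swapping an Isopropyl for a Pyridine on the Amine Side Chain

The source may report more compounds than this note shows. Statements on the series, on what has been measured and on what is new or still open speak of the compounds shown alone.

Three compounds sharing one core have been characterised in a physicochemical assay for acid dissociation. Compound 1 `Cc1csc2cc([C@H](C)Nc3ncnc(N)c3C#N)c(-c3cccc(CN4CCC(N(C)CC(C)C)CC4)c3)c(=O)n12` gives 9.7. Compound 2 `Cc1csc2cc([C@H](C)Nc3ncnc(N)c3C#N)c(-c3cccc(CN4CCC(CN(C)CC(C)C)CC4)c3)c(=O)n12` gives 9.8, the highest of the three numbers, though the step of a number 0.10 log units higher from compound 1 to compound 2 (within the scatter) lies within the scatter, so the two cannot be ranked. Compound 3 `Cc1csc2cc([C@H](C)Nc3ncnc(N)c3C#N)c(-c3cccc(CN(C)CCCN(C)Cc4ccc(Cl)cc4)c3)c(=O)n12` gives 8.8, which is well below compound 2 and beyond the scatter, but compound 3 differs from compound 2 in more than one place, so no single step can be read from that pair.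

Compound 4 `Cc1csc2cc([C@H](C)Nc3ncnc(N)c3C#N)c(-c3cccc(CN4CCC(CN(C)Cc5ccccn5)CC4)c3)c(=O)n12` is not yet measured. It differs from compound 2 in one place: pyridin-2-yl in place of isopropyl on a saturated chain carbon bound to an amine nitrogen. For the measured compounds named here, the only single step measured so far, from compound 1 to compound 2, moved an intact isobutyl(methyl)amino group one bond further out and changed nothing beyond the scatter; it does not test the exchange of an isopropyl for a pyridin-2-yl. Going by the values given here, there is therefore no direct precedent, only the observation that compound 3, with a different amine arrangement, sits a full unit lower.

Compound 4 is expected to fall below compound 2 by the step of a number 0.90 log units lower from compound 2 to compound 4 (beyond the scatter), beyond the scatter. Compound 4 is estimated at 8.9, between 8.3 and 9.5.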

Compound 4, acid dissociation constant: 9
For compound 4 the middle estimate is 0.10 log units below the measured one; low and high end bracket the measured number.
By their numbers in this assay, from the lowest: compounds 3 and 4 (each within the scatter of the next); then compounds 1 and 2 (each within the scatter of the next).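

In this assay, for the compounds shown here, pyridin-2-yl in place of isopropyl on a saturated chain carbon bound to an amine nitrogen produces a number 0.80 log units lower from compound 2 to compound 4 (beyond the scatter) and so takes the number beyond the scatter, which the only earlier single step, a number 0.10 log units higher from compound 1 to compound 2 (within the scatter) with (isobutyl(methyl)amino)methyl in place of isobutyl(methyl)amino, did not do. The wider comparison points the same way, giving a number 0.70 log units lower from compound 1 to compound 4 (beyond the scatter) for (methyl((pyridin-2-yl)methyl)amino)methyl in place of isobutyl(methyl)amino on a saturated ring carbon, so among these three compounds the number responds to the exchange of the group at the end of the side chain and not to the step that leaves isobutyl(methyl)amino intact. No supporting measurement is available that would explain this shift.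

The compounds shown do not separate the contribution of the aromatic ring from that of its ring nitrogen, a comparison that a phenyl group in place of the pyridin-2-yl would provide. They also leave open how pyridin-3-yl, pyridin-4-yl or a saturated ring such as cyclohexyl would read at this same place.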